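Dichlorobenzyl in place of fluorobenzyl on the pyrazole amides

This account rests on a few compounds, and the source may have more. Where it says the series, first, only, none or still open, it means among the compounds named here.

The measured compounds and their values:
compound 1 `Cc1ccc(-c2nn(-c3ccccc3)cc2C(=O)NOCc2ccc(Cl)cc2Cl)cc1` with 1080 nM
compound 2 `O=C(NOCc1ccccc1)c1cn(-c2ccccc2)nc1-c1ccc(F)cc1` with 10400 nM
compound 3 `O=C(NOCc1ccccc1F)c1cn(-c2ccccc2)nc1-c1ccc(F)cc1` with 17500 nM

Compound 3 gives 17500 nM in a functional assay on A549 cells (Homo sapiens) for antiproliferative activity, read by MTT assay, with a stated time of 48 h, in the presence of a further agent that is not named here (on this read-out lower numbers stand for stronger inhibition of growth and higher numbers for weaker inhibition of growth), the highest of the three numbers. Its nearest neighbour is compound 2, and the step of a 1.7-fold higher number from compound 2 to compound 3 (0.23 log units; within the scatter) lies within the scatter. Compound 1 stands furthest away, with a lower number beyond the scatter, but compound 1 differs from compound 3 in two places, so no single step can be read from that pair.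

Compound 4 `O=C(NOCc1ccc(Cl)cc1Cl)c1cn(-c2ccccc2)nc1-c1ccc(F)cc1` has not yet been measured. It differs from compound 3 by 2,4-dichlorophenyl in place of 2-fluorophenyl on a saturated chain carbon bound to an oxygen. Among the measured compounds shown here, no measured step covers this exchange: the only step that touches the benzyl part, the one from compound 2 to compound 3, is a fluoro for hydrogen swap and stays within the scatter. For the measured compounds named here, compound 1, the one compound carrying the 2,4-dichlorobenzyl group, shows the lowest number of the set, which suggests that compound 4 may move toward a lower number, though the aryl on its core is that of compound 3 rather than of compound 1. Compound 4 is therefore expected to give 3500 nM in this assay, between 900 nM and 14000 nM, a step of a 5.0-fold lower number from compound 3 to compound 4 (0.70 log units; beyond the scatter) that is expected but uncertain.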

Compound 4, concentration for 50% growth inhibition: 14000 nM
Compound 4: middle estimate off by 4.0-fold (0.60 log units), on the low side, within the range that was stated.
By their numbers in this assay, from the lowest: compound 1; then compounds 2, 4 and 3 (each within the scatter of the next).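

In this assay, the group on the saturated chain carbon bound to an oxygen does little on the core of compound 4: 2,4-dichlorophenyl in place of 2-fluorophenyl gives a 1.3-fold lower number from compound 3 to compound 4 (0.10 log units; within the scatter), and 2,4-dichlorophenyl in place of phenyl gives a 1.3-fold higher number from compound 2 to compound 4 (0.13 log units; within the scatter), so the three aryl groups at this place cannot be told apart. The large difference lies at the other place, where fluoro in place of methyl on an aromatic carbon, with the 2,4-dichlorobenzyl group unchanged, gives a 13-fold higher number from compound 1 to compound 4 (1.11 log units; beyond the scatter), so the low number of compound 1 goes with its methyl and cannot be credited to the 2,4-dichlorobenzyl group alone. No measurement at hand offers an explanation for either finding.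

Compound 1 is the only compound shown with the methyl group, so it remains open whether the methyl group would lower the number to the same extent alongside an unsubstituted benzyl or a 2-fluorobenzyl group. Also open, going by these compounds, is how an ethyl, a methoxy or an amine on that aromatic carbon would read in this assay.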